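Ethynyl in Place of Butyl on a Biaryl Amide

The source may report more compounds than this note shows. Statements on the series, on what has been measured and on what is new or still open speak of the compounds shown alone.

Compound 1 `CCCCc1cc(C(=O)N[C@H](C)CCCc2cccnc2)ccc1-c1ccc(OC)c(OC)c1` is the stronger of the two compounds measured in an assay (Canis lupus familiaris) for binding affinity to platelet-activating factor receptor (Homo sapiens), read by radioligand binding (a higher number here means a weaker inhibitor, a lower number a stronger inhibitor), where compound 1 gives 4 nM. Compound 2 `COc1cccc(-c2ccc(C(=O)NCCCCc3cccnc3)cc2)c1` gives 280 nM in this assay; the gap between the two is beyond the scatter, so compound 1 stands lowest of the two numbers. Among the measured compounds shown here, compound 2 and compound 1 differ in several places at once, so no single step connects them, and nothing can be read from their pair about any one change.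

Compound 3 `C#Cc1cc(C(=O)N[C@H](C)CCCc2cccnc2)ccc1-c1ccc(OC)c(OC)c1` has not yet been measured in this assay. It differs from compound 1 in one place: ethynyl in place of butyl on an aromatic carbon. The change sits on an aromatic carbon of a six-membered aromatic ring of carbon only, ortho to a 3,4-dimethoxyphenyl group. For the measured compounds named here, no measured pair shows what such an exchange does, so the expectation rests on compound 1 alone. A modest weakening is expected, a 3.8-fold higher number from compound 1 to compound 3 (0.57 log units; beyond the scatter), with the outcome plausibly also within the scatter of compound 1. Compound 3 is estimated at 15 nM, with a range from 3 nM to 70 nM.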

Compound 3, half-maximal inhibitory concentration: 5 nM
Compound 3: middle estimate off by 3.0-fold (0.48 log units), on the high side; the measured number falls inside the stated range.
By their numbers in this assay, from the lowest: compounds 1 and 3 (each within the scatter of the next); then compound 2.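

Placing ethynyl where compound 1 carries butyl gives the first reading at this position, on an aromatic carbon ortho to a 3,4-dimethoxyphenyl group and meta to a large group, and in this assay the exchange stays within the scatter (a 1.3-fold higher number from compound 1 to compound 3 (0.10 log units; within the scatter)). Butyl, with 4 heavy atoms, and ethynyl, with 2 heavy atoms and a triple bond outside aromatic rings, therefore cannot be told apart by their numbers on this core, which shows that the full butyl chain is not required here to keep a number at the level of compound 1. Nothing at hand bears on why the two groups read alike.

With only butyl and ethynyl shown at this position, it remains open how a methyl, a nitrile, an amine or a carboxylic acid would read there, and whether a chain longer than butyl would hold the number. From the compounds shown here alone, it is also open whether the exchange would read the same if a simple phenyl took the place of the 3,4-dimethoxyphenyl group.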